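Swapping a Sulfanyl Thiazole for an Oxy Dichloropyridazine

The source may report more compounds than this note shows. Statements on the series, on what has been measured and on what is new or still open speak of the compounds shown alone.

Three compounds share a core and differ only in the group on a saturated chain carbon bound to a carbonyl carbon. Compound 1 `COC(=O)c1cc(OCC(=O)[C@H](CC(=O)O)NC(=O)[C@@H](NC(=O)COc2cccc3ccccc23)C(C)C)no1` carries (5-(methoxycarbonyl)-1,2-oxazol-3-yl)oxy there, and in a functional assay on Jurkat cells (Homo sapiens) for inhibition (on this read-out lower numbers stand for stronger inhibition and higher numbers for weaker inhibition), compound 1 gives 71000 nM. Compound 3 `CC(C)[C@H](NC(=O)COc1cccc2ccccc12)C(=O)N[C@@H](CC(=O)O)C(=O)CSc1nc(-c2ccccc2)no1` carries (3-phenyl-1,2,4-oxadiazol-5-yl)sulfanyl; in this assay compound 3 gives 102000 nM, with a 1.4-fold higher number from compound 1 to compound 3 (0.16 log units; within the scatter). Compound 2 `CC(C)[C@H](NC(=O)COc1cccc2ccccc12)C(=O)N[C@@H](CC(=O)O)C(=O)CSc1nc(-c2ccccc2)cs1` carries (4-phenyl-1,3-thiazol-2-yl)sulfanyl. Among the compounds with values here, for compound 2 this assay reports only a limit, > 200000 nM, so compound 2 is the one value that sits at the limit of > 200000 nM in this assay, at which 1 of the 3 values shown sits. Accordingly an at least 2.8-fold higher number from compound 1 to compound 2 (0.44 log units; beyond the scatter) and an at least 1.9-fold lower number from compound 2 to compound 3 (0.29 log units; that floor lies within the scatter) are known only as bounds.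

Compound 4 `CC(C)[C@H](NC(=O)COc1cccc2ccccc12)C(=O)N[C@@H](CC(=O)O)C(=O)COc1nncc(Cl)c1Cl` introduces the change ((4,5-dichloropyridazin-3-yl)oxy in place of (4-phenyl-1,3-thiazol-2-yl)sulfanyl on a saturated chain carbon bound to a carbonyl carbon). This returns to an oxygen-linked heteroaryl ring, as in compound 1, whose value of 71000 nM is the closest guide. The expected step is an at least 2.5-fold lower number from compound 2 to compound 4 (0.39 log units; beyond the scatter), a lower number for compound 4 than the limit of compound 2. Compound 4 is estimated at 80000 nM, within 30000 nM to 200000 nM.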

Compound 4, half-maximal inhibitory concentration: > 200000 nM
Compound 4 ended at the assay's limit (the forecaster's own chance of this, stated with the estimate: 25%); middle value at least 2.5-fold (0.39 log units) from the limit.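

With the oxygen link kept and only the ring changed, 4,5-dichloropyridazin-3-yl in place of 5-(methoxycarbonyl)-1,2-oxazol-3-yl gives an at least 2.8-fold higher number from compound 1 to compound 4 (0.44 log units; beyond the scatter), so an oxygen-linked ring at this position does not by itself give a readable value. Against the sulfur-linked compound 3, the result is less firm: an at least 1.9-fold higher number from compound 3 to compound 4 (0.29 log units; that floor lies within the scatter). Compound 4 gives only a limit, as does compound 2, so the step between them cannot be read, and limits now make up much of this small set: the limit of > 200000 nM in this assay, at which 2 of the 4 values shown sit.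

Going by these compounds, it remains open whether an amine in place of one chlorine on the pyridazine ring would bring compound 4 back into the readable range. Also open, on these data alone, is whether a sulfur link in place of the oxygen would change its result.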